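Amino Substitution on Two Related Quinolone Cores

The source may hold more compounds than are shown below. What is called first, only, known or untested is meant among the compounds shown, and "the series" means these compounds.

The study compares three measured compounds and one that awaits measurement in a functional assay on AGS cells (Homo sapiens) for cytotoxicity, read by sulforhodamine B assay, with a stated time of 48 h; a higher number here means a weaker inhibitor, a lower number a stronger inhibitor. Compound 1 `CCn1cc(-c2nc3ccccc3[nH]2)c(=O)c2cc(F)c(N3CCNCC3)cc21` gives only a limit in this assay, > 10000 nM. Compound 3 `CCn1cc(-c2nc3ccc(N)cc3[nH]2)c(=O)c2cc(F)c(N3CCNCC3)cc21` gives 10000 nM. Going from compound 1 to compound 3 the change is amino in place of hydrogen on an aromatic carbon, and the step is a number no higher from compound 1 to compound 3 (the limit leaves the size open); its size stays open because the limit of > 10000 nM in this assay, at which 1 of the 3 values shown sits, is what compound 1 shows. Compound 2 `CCn1cc(-c2nc3ccccc3[nH]2)c(=O)c2cc(F)c(N3CCNCC3)nc21` gives 6600 nM; the difference between its core and that of compound 1 is not broken down here. The gap between compound 2 and compound 3 lies within the scatter, so no order is read from it.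

Compound 4 `CCn1cc(-c2nc3ccc(N)cc3[nH]2)c(=O)c2cc(F)c(N3CCNCC3)nc21` carries the same change on the core of compound 2: amino in place of hydrogen on an aromatic carbon. The step from compound 2 to compound 4 is expected to be a 1.0-fold lower number from compound 2 to compound 4 (0.01 log units; within the scatter), resting on the open-sized step from compound 1 to compound 3, a number no higher from compound 1 to compound 3 (the limit leaves the size open), which gives no sign of a large shift. Compound 4 is therefore estimated at 6500 nM, with a range from 2500 nM to 15000 nM.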

Compound 4, half-maximal inhibitory concentration: 9200 nM
Compound 4: the middle estimate sits 1.4-fold (0.15 log units) below what was measured; low and high end bracket the measured number.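

On the core of compound 2, amino in place of hydrogen on an aromatic carbon gives, in this assay, a 1.4-fold higher number from compound 2 to compound 4 (0.14 log units; within the scatter), so no shift can be read from the change on this core. Set beside the same change on the core of compound 1, the comparison stays unsettled: the same change on two cores in this assay, a number no higher (the limit leaves the size open) from compound 1 to compound 3 and a 1.4-fold higher number (0.14 log units; within the scatter) from compound 2 to compound 4; the limit leaves it open whether they differ Compound 1 is known only as a limit, so the step on its core cannot be read, and the data do not show whether the change carries from one core to the other with the same size: the limit of > 10000 nM in this assay, at which 1 of the 4 values shown sits.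

The compounds shown hold only hydrogen and amino at this place, so what a methoxy group or a carboxylic acid would do there remains open. As far as these compounds go, all four values come from this assay, so whether the amino change would behave in the same way in a different cell line also remains open.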